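A Polar Amide Replaces a Propyl Tail

The compounds below may be only part of what the source reports. "The series", "measured", "known", "first", "only" and "open" are said of these compounds alone.

Compound 1 `CCC[C@H]1C[C@@H](O)[C@@H](O)C1`: in an ADME assay on S2 cells (Drosophila melanogaster) for cytotoxicity, read by MTT assay (a higher number here means that more compound is needed for the effect, a lower number that less compound is needed), compound 1 reaches only a limit, > 350000 nM.
Compound 2 `CCCCCC[C@H]1C[C@@H](O)[C@@H](O)C1`: in this assay compound 2 gives 110000 nM.

Among the compounds with values here, compound 2 carries the only firm number here; the other value is a limit (the limit of > 350000 nM in this assay, at which 1 of the 2 values shown sits). Lengthening the chain lowered the number, an at least 3.1-fold lower number from compound 1 to compound 2 (0.50 log units; beyond the scatter). Compound 3 `CNC(=O)CCC[C@H]1C[C@@H](O)[C@@H](O)C1` differs from compound 2 by methylcarbamoyl in place of propyl on a saturated chain carbon, three bonds along the chain from a saturated ring carbon. Within the data shown here, only that one earlier step bears on this change, and it involved adding carbon rather than exchanging the chain end for an amide, so it is a weak guide. A modest rise is expected in this assay, a 2.3-fold higher number from compound 2 to compound 3 (0.36 log units; beyond the scatter). Compound 3 is therefore estimated at 250000 nM, within 80000 nM to 600000 nM.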

Compound 3, half-maximal effective concentration: > 250000 nM
Compound 3 gave a limit, no number; the forecaster's own chance of this, stated with the estimate: 40%; the middle value lies on the limit itself.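

In this assay, methylcarbamoyl in place of propyl gives an at least 2.2-fold higher number from compound 2 to compound 3 (0.35 log units; beyond the scatter), so the number responds to what forms the chain end, not only to added carbon. Compound 3 gives only a limit, not a firm number: the limit of > 250000 nM in this assay, at which 1 of the 3 values shown sits.
Compound 1 also gives only a limit, so the step between compound 1 and compound 3 cannot be read: the limit of > 350000 nM in this assay, at which 1 of the 3 values shown sits.

On these data alone, the full size of the rise for compound 3 stays open. Also open, as far as these compounds go, are whether a carboxylic acid or an amine at this chain end would act like methylcarbamoyl, and whether a longer chain would lower the number further.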